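Benzyl sulfanyl swap on the shared core: compound 3

A few compounds are considered here, and "the series" means these few. Any claim that something is new, unique, unknown or untested is made for them only; others in the source may bear on it.

Measured in a functional assay on HepG2 cells (Homo sapiens) for antiproliferative activity, read by MTT assay, with a stated time of 24 h; on this read-out higher numbers stand for weaker inhibition and lower numbers for stronger inhibition:
- compound 1 `Sc1nnc(-c2ccc3c(c2)OCCO3)n1-c1ccccc1`: 60000 nM
- compound 2 `Clc1cccc(CSc2nnc(-c3ccc4c(c3)OCCO4)n2-c2ccccc2)c1`: 2390 nM

Among the measured compounds shown here, of the two measured compounds, compound 2 has the lower number at 2390 nM, and the only measured comparison puts it clearly ahead of compound 1 at 60000 nM. Compound 3 `Cc1ccccc1CSc1nnc(-c2ccc3c(c2)OCCO3)n1-c1ccccc1` has not been measured. It differs from compound 2 as follows: 2-methylphenyl in place of 3-chlorophenyl on a saturated chain carbon bound to a sulfur. In words, 2-methylphenyl stands in place of 3-chlorophenyl on a saturated chain carbon bound to a sulfur, so 3-chlorobenzyl becomes 2-methylbenzyl.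

For the measured compounds named here, one measured step bears on this change, and it is large: a 25-fold lower number from compound 1 to compound 2 (1.40 log units; beyond the scatter). That step brought in 3-chlorobenzyl as a whole. Going by the values given here, no measured pair compares 3-chlorophenyl with 2-methylphenyl, so it gives only a loose guide. Compound 3 still carries a benzyl group on the sulfur, so most of that gain is expected to remain. The expected step is a 1.5-fold higher number from compound 2 to compound 3 (0.17 log units; within the scatter), much smaller than the measured one, and its direction is only weakly held. In this assay the estimate for compound 3 is 3500 nM, with an expected range of 1200 nM to 11000 nM.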

Compound 3, half-maximal inhibitory concentration: 20500 nM
For compound 3 the middle estimate is 5.9-fold (0.77 log units) below the measured one; measured number above the stated range.
By their numbers in this assay, from the lowest: compound 2; then compound 3; then compound 1.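

In this assay, the benzyl group on the sulfur does not set the level of inhibition by itself, since exchanging 3-chlorobenzyl for 2-methylbenzyl gives an 8.6-fold higher number from compound 2 to compound 3 (0.93 log units; beyond the scatter) and so the substituted phenyl ring matters at this position. Compound 3 still keeps part of the gain over the free sulfanyl compound, with a 2.9-fold lower number from compound 1 to compound 3 (0.47 log units; beyond the scatter) for 2-methylbenzyl in place of hydrogen on the sulfur, a smaller step than a 25-fold lower number from compound 1 to compound 2 (1.40 log units; beyond the scatter) for 3-chlorobenzyl, so the size of the gain depends on which benzyl group is attached. No available data bear on why these two benzyl groups differ.

The 3-chlorobenzyl to 2-methylbenzyl change alters both the substituent and its place on the phenyl ring, so the shown compounds cannot separate chlorine versus methyl from the effect of where that group sits. Also open, on these data alone, is how an unsubstituted benzyl group, a longer chain such as 2-phenylethyl, or a chain ending in a carboxylic acid or an amine would read on the same sulfur of the shared core.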